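This account rests on a few compounds, and the source may have more. Where it says the series, first, only, none or still open, it means among the compounds named here.

Working notes on the series.

Compound 1 `Cc1nn(C)c2c1C(c1cccc(Cl)c1)=NCCN2C` and compound 2 `CCN1CCN=C(c2cccc(Cl)c2)c2c(C)nn(C)c21` share one core; compound 3 `Cc1nn(C)c2c1C(c1cccc(F)c1)=NCCN2` carries a core whose difference from that of compound 1 is not broken down here. Compound 4 `CCc1nn(C)c2c1C(c1cccc(F)c1)=NCCN2` is built on the core of compound 3 and is not yet measured.

In a functional assay on the whole organism for positive allosteric modulation, with Rattus norvegicus as the target (on this read-out lower numbers stand for an effect already at smaller amounts and higher numbers for an effect only at larger amounts of compound), compound 1 gives 0.63 mg/kg. Compound 2 gives 0.63 mg/kg in this assay, so no change at the digits printed from compound 1 to compound 2 (within the scatter); that step is methyl in place of hydrogen on a saturated chain carbon bound to a nitrogen on an aromatic ring in a ring. In this assay compound 3 gives 2.5 mg/kg, the highest of the three numbers, with its gap to compound 1 and to compound 2 each beyond the scatter.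

The step from compound 3 to compound 4 is methyl in place of hydrogen on a saturated chain carbon bound to an aromatic carbon. For the measured compounds named here, it is the same kind of change as the one from compound 1 to compound 2, methyl entering for hydrogen, but not the same: in the earlier case the place was a saturated chain carbon bound to a nitrogen on an aromatic ring in a ring, here it is a saturated chain carbon bound to an aromatic carbon. Going by the values given here, the only measured example of a methyl for hydrogen step left the number unchanged within the scatter, and no pair in the data tests a methyl entering on a carbon bound to an aromatic carbon.

On that basis a small step is expected for compound 4, no change at the digits printed from compound 3 to compound 4 (within the scatter), resting on the unchanged value of compound 2 after no change at the digits printed from compound 1 to compound 2 (within the scatter). Compound 4 is therefore estimated at 2.5 mg/kg in this assay, with 1 mg/kg to 6.3 mg/kg as the expected range.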

Compound 4, minimum effective dose: 2.5 mg/kg
Compound 4: middle estimate and measured number agree at the digits printed; the range from low to high includes it.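

In this assay, methyl in place of hydrogen on a saturated chain carbon bound to an aromatic carbon gives no change at the digits printed from compound 3 to compound 4 (within the scatter), and set beside the earlier methyl for hydrogen step, the result carries over from one core to the other: the same change on two cores in this assay, no change at the digits printed (within the scatter) from compound 1 to compound 2 and no change at the digits printed (within the scatter) from compound 3 to compound 4, 1.0-fold (0.00 log units) apart, within the scatter of two such steps

What this shows is limited to two pairs, in each of which one added methyl leaves the read-out where it stood, on the core of compound 1 and on the core of compound 3 alike. It does not show that the place of the methyl is irrelevant, since the earlier step sits on a saturated chain carbon bound to a nitrogen on an aromatic ring in a ring, the new one sits on a saturated chain carbon bound to an aromatic carbon, and no pair shown puts the methyl at the same place on both cores.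

The compounds shown leave open whether the flat result holds on any further core, and whether it would survive a group larger or different from methyl. A longer chain such as propyl, or an amine or a carboxylic acid, on the saturated chain carbon bound to an aromatic carbon would be the next question for this read-out.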